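Thiophen-3-yl to 3,4-difluorophenyl on the carbonyl

The source may report more compounds than this note shows. Statements on the series, on what has been measured and on what is new or still open speak of the compounds shown alone.

In a functional assay on A2780 cells (Homo sapiens) for antiproliferative activity, read by fluorescence, with a stated time of 72 h (on this read-out lower numbers stand for stronger inhibition and higher numbers for weaker inhibition), compound 3 (`CN1CCC(C(=O)N2Cc3c(NC(=O)c4ccsc4)n[nH]c3C2(C)C)CC1`) gives 140 nM and stands level with compound 1 (`CN1CCC(C(=O)N2Cc3c(NC(=O)C4CCC4)n[nH]c3C2(C)C)CC1`) at 140 nM as the lowest of the three numbers, while compound 2 (`CN1CCC(C(=O)N2Cc3c(NC(=O)NCc4ccccc4)n[nH]c3C2(C)C)CC1`) gives 2680 nM in the same read-out. Compound 4 (`CN1CCC(C(=O)N2Cc3c(NC(=O)c4ccc(F)c(F)c4)n[nH]c3C2(C)C)CC1`) carries 3,4-difluorophenyl in place of thiophen-3-yl on a carbonyl carbon. Going by the values given here, the closest precedent is no change at the digits printed from compound 1 to compound 3 (within the scatter) for thiophen-3-yl in place of cyclobutyl. The large moves a 19-fold higher number from compound 1 to compound 2 (1.28 log units; beyond the scatter) and a 19-fold lower number from compound 2 to compound 3 (1.28 log units; beyond the scatter) both involve benzylamino, which compound 4 does not carry. No step beyond the scatter is therefore expected in this assay and the estimated move is a 1.1-fold higher number from compound 3 to compound 4 (0.06 log units; within the scatter) for now. Compound 4 is expected at 160 nM within an estimated range of 50 nM to 500 nM on this evidence.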

Compound 4, half-maximal inhibitory concentration: 100 nM
The estimate for compound 4 lay 1.6-fold (0.20 log units) above the measured number, within the range that was stated.
By their numbers in this assay, from the lowest: compounds 4, 1 and 3 (each within the scatter of the next); then compound 2.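

In this assay the larger 3,4-difluorophenyl ring on the carbonyl holds the level of the smaller groups: a 1.4-fold lower number from compound 3 to compound 4 (0.15 log units; within the scatter) and a 1.4-fold lower number from compound 1 to compound 4 (0.15 log units; within the scatter) are both within the scatter, so these three groups cannot be separated here. Compound 2 alone stands apart, with a 27-fold lower number from compound 2 to compound 4 (1.43 log units; beyond the scatter) and benzylamino as the only difference. No measurement here bears on the reason for these readings. Still open, going by these compounds, is whether an aminomethyl or carboxylic acid group on the phenyl ring, or a longer alkyl chain on the carbonyl, would keep this level.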